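The compounds below may be only part of what the source reports. "The series", "measured", "known", "first", "only" and "open" are said of these compounds alone.

Compound 1 `CC(C)Oc1ccc(C(O)(c2ccc(C(F)(F)F)cc2)c2cccnc2)cc1`: 47600 nM
Compound 2 `CN(C)c1ccc(C(O)(c2ccc(C(F)(F)F)cc2)c2cccnc2)cc1`: 59100 nM

Both values come from an ADME assay on L6 cells (Rattus norvegicus) for cytotoxicity, read by resazurin assay, with a stated time of 72 h; a lower number here means a stronger inhibitor, a higher number a weaker inhibitor. Compound 2, at 59100 nM, lies within the scatter of compound 1, at 47600 nM, so the two cannot be told apart.

Compound 3 `OC(c1ccc(C(F)(F)F)cc1)(c1ccc(C(F)(F)F)cc1)c1cccnc1` differs from compound 2 at one place: trifluoromethyl in place of dimethylamino on an aromatic carbon. This puts trifluoromethyl in place of dimethylamino on an aromatic carbon, para to a large group.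

Within the data shown here, one measured step bears on this place: a 1.2-fold higher number from compound 1 to compound 2 (0.09 log units; within the scatter), with dimethylamino in place of isopropoxy. Trifluoromethyl has not been measured there, and a single step is thin support. Resting on that step, no change beyond the scatter is expected in this assay. The estimated change is a 1.3-fold lower number from compound 2 to compound 3 (0.12 log units; within the scatter). For compound 3 the expected value is 45000 nM, with an estimated range of 18000 nM to 100000 nM.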

Compound 3, half-maximal inhibitory concentration: 50600 nM
Compound 3: middle estimate off by 1.1-fold (0.05 log units), on the low side, and the stated range covers the measured number.
By their numbers in this assay, from the lowest: compounds 1, 3 and 2 (each within the scatter of the next).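

In this assay, trifluoromethyl on this aromatic carbon gives a 1.2-fold lower number from compound 2 to compound 3 (0.07 log units; within the scatter) when set against dimethylamino, and a 1.1-fold higher number from compound 1 to compound 3 (0.03 log units; within the scatter) when set against isopropoxy. Among these compounds, the single earlier step compared only isopropoxy and dimethylamino; the same reading now extends to a group with no hydrogen-bond acceptor, so none of the three groups can be told apart at this place. Nothing measured here accounts for this lack of separation.

From the compounds shown here alone, whether a carboxylic acid, a primary amine or a longer alkoxy chain at this place would give a step beyond the scatter remains open. Also open, going by these compounds, is whether the same reading would hold with a change elsewhere, as all three compounds keep the rest of the core of compound 1.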